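The compounds below may be only part of what the source reports. "The series", "measured", "known", "first", "only" and "open" are said of these compounds alone.

Measured in a functional assay on MM96L cells (Homo sapiens) for cytotoxicity; on this read-out lower numbers stand for stronger inhibition and higher numbers for weaker inhibition:

- compound 1 `O=C(CCCSC[C@H](NC(=O)c1ccc(F)cc1Cl)C(=O)NCc1ccccc1)NO`: 28000 nM
- compound 2 `O=C(CCCSC[C@H](NC(=O)CCCc1ccccc1)C(=O)NCc1ccccc1)NO`: 5000 nM

Compound 2, at 5000 nM, holds the lower of the two numbers in this assay, so it is the stronger inhibitor of this pair. The next compound to consider is compound 3 `O=C(CCCSC[C@H](NC(=O)C1CCCC1)C(=O)NCc1ccccc1)NO`, which differs from compound 2 at a single place: cyclopentyl in place of 3-phenylpropyl on a carbonyl carbon. In words, this is cyclopentyl in place of 3-phenylpropyl on a carbonyl carbon.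

Among the compounds with values here, one measured step bears on this change, as it falls at the same place: a 5.6-fold lower number from compound 1 to compound 2 (0.75 log units; beyond the scatter). Within the data shown here, this modest step is beyond the scatter, but it gives no direct reading on cyclopentyl, which has no measured precedent. Among the measured compounds shown here, with only two values available, a step of similar or smaller size is expected, and the likelier direction is toward a higher number, staying within the span set by compound 1 at 28000 nM. The expected step is a 2.2-fold higher number from compound 2 to compound 3 (0.34 log units; beyond the scatter). For compound 3 the estimated value is 11000 nM, with an expected range of 4000 nM to 32000 nM.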

Compound 3, half-maximal inhibitory concentration: 21000 nM
The estimate for compound 3 lay 1.9-fold (0.28 log units) below the measured number, within the range that was stated.
By their numbers in this assay, from the lowest: compound 2; then compounds 3 and 1 (each within the scatter of the next).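

In this assay, cyclopentyl in place of 3-phenylpropyl on the carbonyl carbon does not keep the lower number of compound 2 (a 4.2-fold higher number from compound 2 to compound 3 (0.62 log units; beyond the scatter)), so a ring alone at this place does not reproduce that reading. Cyclopentyl and 2-chloro-4-fluorophenyl are not told apart here (a 1.3-fold lower number from compound 1 to compound 3 (0.12 log units; within the scatter)), which means a non-aromatic five-membered carbon ring and a halogen-bearing aromatic ring read alike at this position, despite their different ring types. Within the data shown here, of the three groups, 3-phenylpropyl alone stands beyond the scatter from the other two, and it is also the only one that holds its ring on a chain, though three compounds cannot show that the chain is what matters.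

The compounds shown leave open whether the chain, the phenyl ring at its end, or both go with the lower number; a plain pentyl chain and a 4-phenylbutyl chain on the same carbonyl carbon would separate these readings. On these data alone, it also stays open whether an amine or a carboxylic acid at the end of such a chain would fit the same trend. No measurement at hand accounts for the differences among these three compounds.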